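The compounds below may be only part of what the source reports. "The series", "measured", "known", "first", "only" and "open" are said of these compounds alone.

In a functional assay on DU-145 cells (Homo sapiens) for antiproliferative activity, read by MTT assay, with a stated time of 24 h (a higher number here means a weaker inhibitor, a lower number a stronger inhibitor), three compounds sharing one core have been measured. Compound 1 `COc1ccc(-c2noc(C3CCNCC3)n2)cc1OC1CCCC1`, with a piperidin-4-yl group, gives 57 nM. Compound 3 `COc1ccc(-c2noc(-c3ccc(O)cc3)n2)cc1OC1CCCC1`, with a 4-hydroxyphenyl group, gives 780 nM. Compound 2 `COc1ccc(-c2noc(-c3ccc(F)cc3)n2)cc1OC1CCCC1`, with a 4-fluorophenyl group, gives 20700 nM, the highest number of the three, which makes it the weakest inhibitor of the set.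

Compound 4 `COc1ccc(-c2noc(-c3ccc(F)cc3)n2)cc1O`, not yet measured, departs from compound 2 at a different place. It has hydrogen in place of cyclopentyl on an oxygen on an aromatic ring, so cyclopentyloxy becomes hydroxy (hydrogen in place of cyclopentyl on an oxygen on an aromatic ring).

Going by the values given here, no measured step touches this place. The three available steps all change a group elsewhere: a 360-fold higher number from compound 1 to compound 2 (2.56 log units; beyond the scatter), a 14-fold higher number from compound 1 to compound 3 (1.14 log units; beyond the scatter) and a 27-fold lower number from compound 2 to compound 3 (1.42 log units; beyond the scatter). All are large, so the numbers in this small set can move far, but they offer only indirect guidance here. The last of them, a hydroxy in place of fluoro, lowered the number, and compound 2 already lies at the weak end at 20700 nM. A modest move towards a lower number is therefore expected, though with little confidence in its direction, and the estimated step is a 1.7-fold lower number from compound 2 to compound 4 (0.24 log units; within the scatter). For compound 4 the estimate is 12000 nM, with an expected range from 2500 nM to 50000 nM.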

Compound 4, half-maximal inhibitory concentration: > 1000000 nM
Compound 4 ended at the assay's limit; the forecaster's own chance of this, stated with the estimate: 20%; middle value at least 83-fold (1.92 log units) from the limit.
By their numbers in this assay, from the lowest: compound 1; then compound 3; then compound 2. At a limit, above all of these: compound 4.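

Hydrogen in place of cyclopentyl on an oxygen on an aromatic ring gives an at least 48-fold higher number from compound 2 to compound 4 (1.68 log units; beyond the scatter), which shows that this place, untouched by the earlier steps, can by itself move the number in this assay by a large amount. The value of compound 4, > 1000000 nM, is a limit of the assay and not a number, so the step has a known lower bound but no known size: the limit of > 1000000 nM in this assay, at which 1 of the 4 values shown sits. With the 4-fluorophenyl group held constant, the cyclopentyloxy group therefore counts for a great deal in this assay, and the change to hydroxy moves the number in the same direction as the earlier step to that 4-fluorophenyl group, though this is seen on that one background only.

The compounds shown leave open whether the same change would have a comparable effect with the piperidin-4-yl group of compound 1 or the 4-hydroxyphenyl group of compound 3. They also leave open how a methoxy, an ethoxy or a cyclohexyloxy group in the same place would read, and so whether the ring of cyclopentyl or simply a carbon group on that oxygen matters.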